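Para substituent swap in the pyridyl enone series

The source may report more compounds than this note shows. Statements on the series, on what has been measured and on what is new or still open speak of the compounds shown alone.

Going by the values given here, compound 3 `O=C(/C=C/c1ccncc1)c1ccc(C(F)(F)F)cc1` gives 204000 nM in a functional assay with Rattus norvegicus as the target (on this read-out higher numbers stand for weaker inhibition and lower numbers for stronger inhibition), the highest of the three numbers measured so far. Compound 1 `N#Cc1ccc(C(=O)/C=C/c2ccncc2)cc1` gives 123000 nM in this assay, and compound 2 `O=C(/C=C/c1ccncc1)c1ccccc1` gives 49000 nM. The step of a 1.7-fold higher number from compound 1 to compound 3 (0.22 log units; within the scatter) is within the scatter, whereas a 4.2-fold higher number from compound 2 to compound 3 (0.62 log units; beyond the scatter) and a 2.5-fold lower number from compound 1 to compound 2 (0.40 log units; beyond the scatter) are beyond it, so among these three the unsubstituted compound 2 stands apart with the lowest number.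

Compound 4 `CSc1ccc(C(=O)/C=C/c2ccncc2)cc1` differs from compound 3 by methylsulfanyl in place of trifluoromethyl on an aromatic carbon. Among the compounds with values here, none of the measured steps involves methylsulfanyl, so the bearing is indirect: both steps that place a group on this aromatic carbon, a 4.2-fold higher number from compound 2 to compound 3 (0.62 log units; beyond the scatter) and a 2.5-fold lower number from compound 1 to compound 2 (0.40 log units; beyond the scatter) read in reverse, raised the number modestly, and the two substituted compounds 1 and 3 sit within the scatter of each other. The expectation for compound 4 in this assay is therefore a number between those of compound 3 and compound 2, with no confident direction beyond the scatter. The expected step is a 1.9-fold lower number from compound 3 to compound 4 (0.27 log units; within the scatter). Compound 4 is estimated at 110000 nM, in a range from 35000 nM to 350000 nM.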

Compound 4, half-maximal inhibitory concentration: 33000 nM
Beside the measured number, compound 4's estimate is 3.3-fold (0.52 log units) above it; measured number below the stated range.
By their numbers in this assay, from the lowest: compounds 4 and 2 (each within the scatter of the next); then compounds 1 and 3 (each within the scatter of the next).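

In this assay, going by these compounds alone, this aromatic carbon now carries a group with no step away from the unsubstituted compound: a 1.5-fold lower number from compound 2 to compound 4 (0.17 log units; within the scatter), so methylsulfanyl and hydrogen cannot be told apart here. The earlier substituted compounds both stood apart from hydrogen, so a group on this carbon does not in itself raise the number. Group identity matters instead, as methylsulfanyl separates from both earlier groups: a 6.2-fold lower number from compound 3 to compound 4 (0.79 log units; beyond the scatter), and a 3.7-fold lower number from compound 1 to compound 4 (0.57 log units; beyond the scatter), leaving compound 2 and compound 4 as one pair and compound 1 and compound 3 as another.

As far as these compounds go, whether an amine, a carboxylic acid or a longer chain on this carbon would join the lower pair or the higher pair stays open. No measured information accounts for methylsulfanyl parting from cyano and trifluoromethyl.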